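The compounds below may be only part of what the source reports. "The series", "measured", "known", "first", "only" and "open" are said of these compounds alone.

Compound 2 `CCN1CCC2(CC1)CC(=O)c1ccc3ccccc3c1O2` and compound 1 `O=C1CC2(CCN(CCC3CCCCC3)CC2)Oc2c1ccc1ccccc21` share one core. In a physicochemical assay for solubility, read by HPLC, at pH 2 (a lower number here means a less soluble compound, a higher number a more soluble compound), compound 2 gives >= 80000 nM, which is a limit of the assay rather than a number (the limit of >= 80000 nM in this assay, at which 1 of the 3 values shown sits). In this assay compound 1 gives 20000 nM. The step of an at least 4.0-fold lower number from compound 2 to compound 1 (0.60 log units; beyond the scatter) goes with cyclohexyl in place of hydrogen on a saturated chain carbon, two bonds along the chain from an amine nitrogen in a ring. Compound 3 `CCN1CCC2(CCc3ccc4ccccc4c3O2)CC1` has another core; how its core differs from that of compound 2 is not broken down here. In this assay compound 3 gives <= 10000 nM, again a limit of the assay and not a number (the limit of <= 10000 nM in this assay, at which 1 of the 3 values shown sits). Compound 4 `c1ccc2c3c(ccc2c1)CCC1(CCN(CCC2CCCCC2)CC1)O3` carries the same change, (cyclohexyl in place of hydrogen on a saturated chain carbon, two bonds along the chain from an amine nitrogen in a ring), on the core of compound 3. The step is expected to be a step that the limit leaves unreadable from compound 3 to compound 4, because the earlier step of an at least 4.0-fold lower number from compound 2 to compound 1 (0.60 log units; beyond the scatter) went that way. Compound 4 is therefore expected to give 3000 nM, somewhere between 500 nM and 10000 nM.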

Compound 4, solubility: 40000 nM
Compound 4: middle estimate off by 13-fold (1.12 log units), on the low side; measured number above the stated range.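

In this assay, adding cyclohexyl gives an at least 4.0-fold higher number from compound 3 to compound 4 (0.60 log units; beyond the scatter), while the same change on the other core gave an at least 4.0-fold lower number from compound 2 to compound 1 (0.60 log units; beyond the scatter), so the change does not keep its direction from one core to the other. Compound 3 stands at a limit and not a number, so the true size of its step stays unread: the limit of <= 10000 nM in this assay, at which 1 of the 4 values shown sits. Compound 2 also stands at a limit and not a number, so the size of its step stays unread too, and these steps show the opposite directions without showing why: the limit of >= 80000 nM in this assay, at which 1 of the 4 values shown sits.

Among the compounds shown here, only this one change on two cores appears here. On these data alone, it remains open whether a phenyl ring, a longer chain or a cyclohexyl ring carrying a carboxylic acid at the same place would follow either direction.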